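Lengthening the Amide Chain of Compound 1

The source may report more compounds than this note shows. Statements on the series, on what has been measured and on what is new or still open speak of the compounds shown alone.

- compound 1 `CCC1C(=O)N(C)c2cnc(-n3ccc4cc(C(=O)NC)ccc43)nc2N1c1ccn(C)n1`: 35400 nM
- compound 2 `CCCNS(=O)(=O)c1ccc(Nc2ncc3c(n2)N(c2ccn(C)n2)C(CC)C(=O)N3C)cc1`: 3000 nM
- compound 3 `CC[C@@H]1C(=O)N(C)c2cnc(-n3ccc4cc(F)ccc43)nc2N1C1CCCC1`: "not active" (no number reported)

In a functional assay on MCF7 cells (Homo sapiens) for antiproliferative activity, read by CCK-8 assay, with a stated time of 72 h (on this read-out lower numbers stand for stronger inhibition of growth and higher numbers for weaker inhibition of growth), compound 1 gives 35400 nM, the higher of the two numbers available, which means the weaker growth inhibition of the pair. The gap down to compound 2 at 3000 nM lies beyond the usual scatter. Compound 3 has no number and so cannot be placed on this scale.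

The next molecule is compound 4 `CCCNC(=O)c1ccc2c(ccn2-c2ncc3c(n2)N(c2ccn(C)n2)C(CC)C(=O)N3C)c1`, which has not yet been measured. It differs from compound 1 in one place: ethyl in place of hydrogen on a saturated chain carbon bound to an amide-type nitrogen. In words, ethyl takes the place of hydrogen on a saturated chain carbon bound to an amide-type nitrogen, so that methylcarbamoyl becomes propylcarbamoyl.

Within the data shown here, no measured pair shows this change on its own, so any forecast is loose. Though it differs from compound 1 in more than that chain, the nearest guide is compound 2, which also ends in propylamino and gives 3000 nM. A moderate move toward a lower number is therefore expected, a 3.0-fold lower number from compound 1 to compound 4 (0.47 log units; beyond the scatter). For compound 4 the estimated value is 12000 nM, with an expected range from 3000 nM to 50000 nM.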

Compound 4, concentration for 50% growth inhibition: 6420 nM
The estimate for compound 4 lay 1.9-fold (0.27 log units) above the measured number; low and high end bracket the measured number.
By their numbers in this assay, from the lowest: compound 2; then compound 4; then compound 1.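

In this assay, among these compounds, the amide chain is the first place where a single change can be read on its own: going from methylcarbamoyl to propylcarbamoyl gives a 5.5-fold lower number from compound 1 to compound 4 (0.74 log units; beyond the scatter). This shows that the end of the amide chain can be altered without losing activity, and that the added ethyl, which brings no ring and no hydrogen-bond donor or acceptor, goes with stronger growth inhibition, though the step is modest. Nothing shown here accounts for this gain, so the reason for it remains unknown.

As far as these compounds go, this single step gives a direction but not a trend, so it remains open whether a longer chain such as butyl or pentyl, a branched chain such as isopropyl, or a chain ending in an amine or a carboxylic acid would lower the number further, leave it unchanged or raise it. Among the compounds shown here, only one pair carries this change, so it also remains open whether propylcarbamoyl would give a step of similar size on a core other than that of compound 1.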